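Morpholine for methylamine on the amide of compound 3

A few compounds are considered here, and "the series" means these few. Any claim that something is new, unique, unknown or untested is made for them only; others in the source may bear on it.

Measured so far:
- compound 1, `O=C(CCc1ccncc1-c1ccc2ccccc2c1)N1CCOCC1`, 100%
- compound 2, `CNC(=O)CCc1ccncc1-c1ccc2ccccc2c1`, 100%
- compound 3, `CNC(=O)/C=C/c1ccncc1-c1ccc2cnn(C)c2c1`, 99%

All three measured compounds were tested in an assay on a protein complex for inhibition of CDK8/Cyclin C (Homo sapiens), with a stated time of 1 h, tested at 10 uM; a lower number here means less inhibition, a higher number more inhibition at the concentration tested (going by the name of the read-out). Compound 2 gives 100% and compound 1 gives 100%; the two differ by one change, (morpholin-4-yl in place of methylamino on a carbonyl carbon), and the step of no change at the digits printed from compound 2 to compound 1 (within the scatter). Compound 3 gives 99%; it shares the carbonyl-bearing side chain with compound 2 but differs in its core, and the difference between the two cores is not broken down here. Its value stands within the scatter of both compound 1 and compound 2, so no order among the three can be read.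

Compound 4, `Cn1ncc2ccc(-c3cnccc3/C=C/C(=O)N3CCOCC3)cc21`, has not yet been measured in this assay. It differs from compound 3 by morpholin-4-yl in place of methylamino on a carbonyl carbon. This is the same kind of change as that from compound 2 to compound 1, though the surroundings of the place differ: in compound 3 the carbonyl carbon neighbours a double-bonded chain carbon, in compound 2 a saturated chain carbon. Since no change at the digits printed from compound 2 to compound 1 (within the scatter), the step of no change at the digits printed from compound 3 to compound 4 (within the scatter) is expected to be similarly flat. On that basis compound 4 is estimated at 99% in this assay, with an expected range from 92% to 100%, resting on the value of compound 3, 99%.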

Compound 4, a percentage reported as inhibition, at one concentration (the size of the read-out at that concentration, not a potency): 89%
The estimate for compound 4 lay 10 percentage points above the measured number; measured number outside the range, below it.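

In this assay, putting morpholin-4-yl in place of methylamino on the carbonyl carbon of compound 3 gives a number 10 percentage points lower from compound 3 to compound 4 (within the scatter). Set beside the same change on the other core, this step shows no difference that can be told from ordinary assay noise: the same change on two cores in this assay, no change at the digits printed (within the scatter) from compound 2 to compound 1 and a number 10 percentage points lower (within the scatter) from compound 3 to compound 4, 10 percentage points apart, within the scatter of two such steps. Among these compounds, as far as this read-out can tell, the change carries from one core to the other without a clear penalty, but this rests on only two pairs, and a percentage at one concentration gives only the size of the effect at that concentration, so it does not show that the two cores respond alike, nor that the compounds within each pair would match at other concentrations.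

The compounds shown leave open whether other amines on the same carbonyl, such as dimethylamine or piperidine, or a carboxylic acid in place of the amide, would fit the same picture. Also open is what a saturated chain would give on the core of compound 3, and what a longer chain would give on either core, with measurements across a full concentration series needed to separate any of these compounds.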